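Methoxy in place of dimethylamino: compound 3 to compound 4

The source may report more compounds than this note shows. Statements on the series, on what has been measured and on what is new or still open speak of the compounds shown alone.

In a functional assay on HSC-2 cells (Homo sapiens) for cytotoxicity, with a stated time of 24 h (a higher number here means that more compound is tolerated, a lower number that less compound is tolerated), compound 1 (`O=C1/C(=C/c2ccccc2)CCC/C1=C\c1cccc([N+](=O)[O-])c1`) gives 3700 nM and compound 2 (`O=C1/C(=C/c2ccc(Cl)cc2)CCC/C1=C\c1cccc([N+](=O)[O-])c1`) gives 2200 nM as the two lower readings. The step separating them (a 1.7-fold lower number from compound 1 to compound 2 (0.23 log units; within the scatter)) stays within the scatter. Compound 3 (`CN(C)c1ccc(/C=C2\CCC/C(=C\c3cccc([N+](=O)[O-])c3)C2=O)cc1`) stands highest of the three at 32000 nM and is the starting point here. Compound 4 (`COc1ccc(/C=C2\CCC/C(=C\c3cccc([N+](=O)[O-])c3)C2=O)cc1`) carries methoxy in place of dimethylamino on an aromatic carbon and is still unmeasured. Within the data shown here, two measured steps bear on this change, both bringing in dimethylamino: the modest one (an 8.6-fold higher number from compound 1 to compound 3 (0.94 log units; beyond the scatter)) and the large one (a 15-fold higher number from compound 2 to compound 3 (1.16 log units; beyond the scatter)). Among the measured compounds shown here, no methoxy compound has been measured, so the expectation rests on these steps alone. Removing dimethylamino is expected to lower the number in this assay by a step close to the modest one. The expected step (a 5.3-fold lower number from compound 3 to compound 4 (0.73 log units; beyond the scatter)) lies beyond the scatter. The estimated value for compound 4 is 6000 nM (2500 nM to 16000 nM).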

Compound 4, half-maximal cytotoxic concentration: 4800 nM
Beside the measured number, compound 4's estimate is 1.3-fold (0.10 log units) above it; the measured number falls inside the stated range.
By their numbers in this assay, from the lowest: compounds 2, 1 and 4 (each within the scatter of the next, the first and the last beyond it); then compound 3.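

Of the groups at this place, para to a large group, dimethylamino stands apart in this assay: a 6.7-fold lower number from compound 3 to compound 4 (0.82 log units; beyond the scatter), although dimethylamino and methoxy carry the same counts of hydrogen-bond donors and acceptors. Methoxy cannot be told apart from hydrogen, with a 1.3-fold higher number from compound 1 to compound 4 (0.11 log units; within the scatter), whereas the step from chloro, a 2.2-fold higher number from compound 2 to compound 4 (0.34 log units; beyond the scatter), lies beyond the scatter and keeps the chloro and methoxy compounds apart. No measurement shown accounts for the separation of compound 3 from compound 4.

From the compounds shown here alone, whether the high number belongs to dimethylamino alone or extends to other amines, such as a primary amine or a pyrrolidine, remains open. The compounds shown also leave unplaced a carboxylic acid or a longer alkoxy chain at this place.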